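Swapping Fluoro for Ethynyl in a Shared Core

A few compounds are considered here, and "the series" means these few. Any claim that something is new, unique, unknown or untested is made for them only; others in the source may bear on it.

Compound 2 `O=C(Nc1cccc(F)c1)c1cc(=O)[nH]c2cc(F)ccc12` was run in a functional assay on KYSE-410 cells (Homo sapiens) for antiproliferative activity, read by MTT assay, with a stated time of 72 h; a higher number here means a weaker inhibitor, a lower number a stronger inhibitor; there compound 2 gave only a limit, > 20000 nM. Compound 1 `O=C(Nc1ccc(Cl)cc1)c1ccnc2cc(Br)ccc12` likewise gave only a limit, > 20000 nM. Among the measured compounds shown here, both results sit at the limit of > 20000 nM in this assay, at which 2 of the 2 values shown sit, so no measured step sets a scale. Compound 3 `C#Cc1ccc2c(C(=O)Nc3cccc(F)c3)cc(=O)[nH]c2c1` is not yet measured; it differs from compound 2 by ethynyl in place of fluoro on an aromatic carbon. With compound 2 at the limit, only a gain could show as a number, and in this assay the step of an at least 1.3-fold lower number from compound 2 to compound 3 (0.12 log units; that floor lies within the scatter) is expected to be modest, not beyond scatter. Compound 3 is estimated at 15000 nM, between 3000 nM and 40000 nM.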

Compound 3, half-maximal inhibitory concentration: 9700 nM
Estimate against measurement, compound 3: 1.5-fold (0.19 log units) above; measured number inside the range.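

Ethynyl in place of fluoro on this aromatic carbon brings an at least 2.0-fold lower number from compound 2 to compound 3 (0.31 log units; beyond the scatter) in this assay and so gives the only number among the compounds shown that is not a limit. This position can therefore register a change in antiproliferative activity, which neither earlier compound could show. The step is a floor and not a full size, since compound 2 stands at a limit: the limit of > 20000 nM in this assay, at which 2 of the 3 values shown sit.

The compounds shown leave open whether an amine, a methyl group or a longer chain on this carbon would match ethynyl. They also leave open why ethynyl lowers the number.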